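The compounds below may be only part of what the source reports. "The series", "measured", "known", "first", "only" and "open" are said of these compounds alone.

Compound 1 `CCC1=C(O)c2c(oc(-c3ccc(SC)cc3)cc2=O)C(CC)(CC)C1=O` carries a 4-(methylsulfanyl)phenyl on the shared core. In a functional assay on KB cells (Homo sapiens) for antiproliferative activity, read by sulforhodamine B assay, with a stated time of 3 days (a lower number here means that less compound is needed, a higher number that more compound is needed for the effect), compound 1 reaches only a limit of the assay, > 52.1 uM. Compound 2 `CCC1=C(O)c2c(oc(-c3cccc(C(F)(F)F)c3)cc2=O)C(CC)(CC)C1=O` gives 35.7 uM in this assay. For compound 3 `CCC1=C(O)c2c(oc(-c3cccc(OC(F)(F)F)c3)cc2=O)C(CC)(CC)C1=O` in this assay only a limit is recorded, > 47.4 uM. Within the data shown here, the single step measured, an at least 1.3-fold higher number from compound 2 to compound 3 (0.12 log units; that floor lies within the scatter), concerns a different exchange and does not bear on the change to compound 4 `CCC1=C(O)c2c(oc(-c3cc(C)c(C)cc3C)cc2=O)C(CC)(CC)C1=O`, which is 2,4,5-trimethylphenyl in place of 4-(methylsulfanyl)phenyl on an aromatic carbon. Among the measured compounds shown here, no measured step covers a change of this kind. All three measured values sit at weak potency, as the limit of > 47.4 uM in this assay, at which 1 of the 3 values shown sits, shows. The same holds for (the limit of > 52.1 uM in this assay, at which 1 of the 3 values shown sits). Compound 4 is therefore expected to stay weak, with an at least 1.3-fold lower number from compound 1 to compound 4 (0.11 log units; that floor lies within the scatter) judged to be no step beyond the scatter, so the estimate is 40 uM, between 12 uM and 120 uM.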

Compound 4, concentration for half-maximal effect: 8.2 uM
Estimate against measurement, compound 4: 4.9-fold (0.69 log units) above; the measured number lies below the stated range.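

In this assay, the exchange gives an at least 6.3-fold lower number from compound 1 to compound 4 (0.80 log units; beyond the scatter), so the position next to the ring oxygen on the shared core can carry a change beyond the scatter. The starting point for this step is only a limit, held by compound 1: the limit of > 52.1 uM in this assay, at which 1 of the 4 values shown sits.

Replacing 4-(methylsulfanyl)phenyl with 2,4,5-trimethylphenyl changes the substituent pattern and removes the sulfur in one step, so the compounds shown cannot separate these two changes. Also open, from the compounds shown here alone, are the effects of a single methyl group, an amine or a carboxylic acid on this phenyl ring.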